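A few compounds are considered here, and "the series" means these few. Any claim that something is new, unique, unknown or untested is made for them only; others in the source may bear on it.

Series notes. For the measured compounds named here, compound 1 `COc1ccc(-c2c(C#N)c(N)c(C#N)c(SC)c2-c2ccccc2)cc1` and compound 2 `CSc1c(C)c(-c2ccccc2)c(C#N)c(N)c1C#N` are the two measured members. In an assay on isolated protein for inhibition of glucose-6-phosphatase catalytic subunit 1 (Homo sapiens), tested at 100 uM (a higher number here means more inhibition at the concentration tested (going by the name of the read-out), a lower number less inhibition), compound 1 gives 37.9%. In this assay compound 2 gives 45%, the higher of the two numbers, though its gap to compound 1 lies within the scatter, so the two values show no order. These two structures differ in more than one place, and no single change can be read from them. Compound 3 `COc1ccc(-c2c(C)c(SC)c(C#N)c(N)c2C#N)cc1` is not yet measured; it differs from compound 2 by methoxy in place of hydrogen on an aromatic carbon. Going by the values given here, no measured pair isolates this change; the nearest guide is that compound 1, which also carries a methoxy, gives 37.9% and sits within the scatter of compound 2. The expected step in this assay is a number 3 percentage points lower from compound 2 to compound 3 (within the scatter), none beyond the scatter in either direction. For compound 3 the expected value is 42%, within a range from 25% to 60%.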

Compound 3, a percentage reported as inhibition, at one concentration (the size of the read-out at that concentration, not a potency): 37.5%
The estimate for compound 3 lay 4.5 percentage points above the measured number; low and high end bracket the measured number.
By their numbers in this assay, from the lowest: compounds 3, 1 and 2 (each within the scatter of the next).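

In this assay methoxy in place of hydrogen on an aromatic carbon, para to a large group, can now be read as a single change: it gives a number 7.5 percentage points lower from compound 2 to compound 3 (within the scatter) and so shows no separable effect at the concentration tested. Methyl in place of phenyl on an aromatic carbon can also be read alone for the first time, and it gives a number 0.4 percentage points lower from compound 1 to compound 3 (within the scatter) with the same outcome, so neither position shows an order in the read-out. No measured evidence bears on either step.

On these data alone, whether an amine or a carboxylic acid on that same aromatic carbon would move the read-out beyond the scatter remains open. As far as these compounds go, it is equally open whether a longer chain such as ethyl or propyl in place of the methyl would separate from compound 3 .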